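The compounds below may be only part of what the source reports. "The series", "measured", "known", "first", "only" and "open" are said of these compounds alone.

The three measured compounds share one core and differ only in the group on a saturated chain carbon bound to an aromatic carbon. Compound 1 `CN1CCC[C@@H]1Cn1nc(Cc2cccc(F)c2)c2ccccc2c1=O` gives 398 nM in an assay for binding affinity to Alpha-1B adrenergic receptor (Homo sapiens); on this read-out lower numbers stand for stronger inhibition and higher numbers for weaker inhibition. Compound 2 `CCCCCc1nn(C[C@H]2CCCN2C)c(=O)c2ccccc12` gives 1000 nM in this assay, and compound 3 `CN1CCC[C@@H]1Cn1nc(Cc2ccc(F)c(F)c2)c2ccccc2c1=O` gives 316 nM in this assay. Compound 3 has the lowest of the three numbers, though the gap to compound 1 lies within the scatter; only compound 2 stands clearly apart, as the step of a 3.2-fold lower number from compound 2 to compound 3 (0.50 log units; beyond the scatter) shows.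

Compound 4 `CN1CCC[C@@H]1Cn1nc(CC2CCCCC2)c2ccccc2c1=O` is not yet measured. It differs from compound 3 by cyclohexyl in place of 3,4-difluorophenyl on a saturated chain carbon bound to an aromatic carbon. Among the compounds with values here, two measured steps bear on this: a 2.5-fold higher number from compound 1 to compound 2 (0.40 log units; beyond the scatter) and a 3.2-fold lower number from compound 2 to compound 3 (0.50 log units; beyond the scatter). Both show that a saturated group on that chain carbon gives a weaker number than an aromatic one. Cyclohexyl is a saturated ring, so compound 4 is expected to move the same way, a modest rise in this assay, with the size a 2.2-fold higher number from compound 3 to compound 4 (0.35 log units; beyond the scatter). Compound 4 is therefore estimated at 700 nM, between 300 nM and 1600 nM.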

Compound 4, inhibition constant: > 1990 nM
Compound 4: no number, only a limit; the forecaster's own chance of this, stated with the estimate: 5%; middle value at least 2.8-fold (0.45 log units) away from the limit.
By their numbers in this assay, from the lowest: compounds 3 and 1 (each within the scatter of the next); then compound 2. At a limit, above all of these: compound 4.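

Compound 4 yields no number in this assay, only a limit: the limit of > 1990 nM in this assay, at which 1 of the 4 values shown sits. Within the data shown here, replacing the aromatic ring with cyclohexyl at this position has a larger effect than the earlier compounds revealed, with an at least 6.2-fold higher number from compound 3 to compound 4 (0.79 log units; beyond the scatter) and an at least 5.0-fold higher number from compound 1 to compound 4 (0.69 log units; beyond the scatter). Having a ring on the saturated chain carbon does not by itself bring back the lower numbers of the aromatic compounds: with cyclohexyl in place of butyl, the step reads an at least 1.9-fold higher number from compound 2 to compound 4 (0.29 log units; that floor lies within the scatter), a floor that does not separate the two compounds.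

The compounds shown leave open how far beyond its limit the true value of compound 4 lies. They also leave open what an unsubstituted benzyl, a pyridine ring or a phenyl ring carrying an amine would give at this position.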